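The source may report more compounds than this note shows. Statements on the series, on what has been measured and on what is new or still open speak of the compounds shown alone.

In an ADME assay on a cell-free system (plasma, Macaca mulatta) for metabolic stability, read by LC-MS, with a stated time of 60 min, tested at 10 uM (a higher number here means that more of the compound is left, a lower number that less of the compound is left), compound 1 `CCOC(=O)[C@H](CCC(=O)C=[N+]=[N-])NC(=O)OCc1oc(=O)oc1C` gives 0% and compound 2 `Cc1oc(=O)oc1COC(=O)N[C@@H](CCC(=O)C=[N+]=[N-])C(=O)OC(C)C` gives 0% at the digits shown, so compound 2 stands level with compound 1 and no compound is left at the end of the incubation. Compound 3 `CC(C)OC(=O)[C@H](CCC(=O)C=[N+]=[N-])NC(=O)OCOC(=O)C(C)(C)C` follows from compound 2 by a group of 7 heavy atoms (5 carbon, 2 oxygen; no ring) in place of a group of 7 heavy atoms (4 carbon, 3 oxygen; one five-membered aromatic ring with 2 hetero atoms), on a saturated chain carbon bound to an oxygen next to a carbonyl group in the carbamate part, so that ((tert-butyl)carbonyl)oxy, which has no ring, stands on the saturated chain carbon bound to an oxygen next to a carbonyl group. For the measured compounds named here, the only measured step is no change at the digits printed from compound 1 to compound 2 (within the scatter) and lies within the scatter, but it sits at a different place and both of its compounds read the same, so it gives no size for this exchange. Going by the values given here, no measured step replaces this group. With compound 2 at 0% a real step can only run upward, yet nothing measured points to one. The expected change is a number 5 percentage points higher from compound 2 to compound 3 (within the scatter) as the working figure, with no step beyond the scatter the likeliest outcome. For compound 3 the estimated value is 5% with an expected range from 0% to 30% in this read-out.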

Compound 3, percent of the compound remaining: 0%
Estimate against measurement, compound 3: 5 percentage points above, and the stated range covers the measured number.
By their numbers in this assay, from the lowest: compounds 1, 2 and 3 (each within the scatter of the next).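

In this assay, replacing the ring-bearing group with ((tert-butyl)carbonyl)oxy on the saturated chain carbon bound to an oxygen next to a carbonyl group gives no change at the digits printed from compound 2 to compound 3 (within the scatter). For the compounds shown here, this is the first reading of a change at this place, and it shows that a group with no ring and one with a five-membered aromatic ring give the same result, with compound 3 at 0%; the earlier step changed a different place and could not show this. The reading cannot rank the two groups, as no compound is left at the end of the incubation with either, and no measured information bears on why the values coincide.

On these data alone, whether any group at this place can leave compound at the end of the incubation remains open, for example an amine, a carboxylic acid or a longer chain in place of ((tert-butyl)carbonyl)oxy. Also open, as far as these compounds go, is whether compound 2 and compound 3 differ at any earlier time point, since a single end reading at the bottom of the scale cannot separate them.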